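A Second Fluorine on the Phenyl Ring

This account rests on a few compounds, and the source may have more. Where it says the series, first, only, none or still open, it means among the compounds named here.

Compound 1, `CC#CC(CC(=O)O)c1ccc(OCc2ccc3nc(-c4ccc(C(C)C)cc4)cn3c2)cc1`: 528 nM
Compound 2, `CC#CC(CC(=O)O)c1ccc(OCc2ccn3cc(-c4ccc(F)cc4)nc3c2)cc1`: 783 nM

Both compounds were tested in an assay on isolated protein for agonist activity at Free fatty acid receptor 1 (Homo sapiens); a higher number here means that more compound is needed for the effect, a lower number that less compound is needed. Compound 2 gives 783 nM there, and compound 1 gives 528 nM. The two numbers sit within the usual scatter of each other, so neither compound can be set apart from the other on this evidence; compound 2 simply has the larger of the two numbers.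

The next compound, compound 3, is `CC#CC(CC(=O)O)c1ccc(OCc2ccn3cc(-c4cc(F)ccc4F)nc3c2)cc1`. It keeps the whole of compound 2 apart from one change: 2,5-difluorophenyl in place of 4-fluorophenyl on an aromatic carbon. For the measured compounds named here, no pair of measured compounds differs by this kind of change, so there is no measured step to lean on. The rest of the molecule, including the acid-bearing chain, is unchanged.

Because compound 2 gives 783 nM and the change is confined to one small aromatic group, the step from compound 2 to compound 3 is expected to be a 1.1-fold lower number from compound 2 to compound 3 (0.05 log units; within the scatter), that is, nothing beyond the scatter in this assay. For compound 3 the estimated value in this assay is 700 nM, with a range from 250 nM to 2000 nM.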

Compound 3, half-maximal effective concentration: 639 nM
Beside the measured number, compound 3's estimate is 1.1-fold (0.04 log units) above it; measured number inside the range.
By their numbers in this assay, from the lowest: compounds 1, 3 and 2 (each within the scatter of the next).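

Putting 2,5-difluorophenyl in place of 4-fluorophenyl, on an aromatic carbon of a five-membered aromatic ring with 2 nitrogen, gives a 1.2-fold lower number from compound 2 to compound 3 (0.09 log units; within the scatter) in this assay. For the compounds shown here, this is the first measured step at this position, and it shows that adding a second fluorine and altering the fluorine pattern on the phenyl ring leaves compound 2 and compound 3 indistinguishable in this assay. No measurement available here offers an explanation for why the two compounds read alike.

On these data alone, both groups seen at this position are fluorine-bearing phenyl rings, so it remains open whether a phenyl ring carrying a nitrile or a methoxy group, or a saturated ring such as morpholine, would shift the number beyond the scatter. As far as these compounds go, it is also open whether the same exchange would give a similar result on the core of compound 1, since this single step comes from the core shared by compound 2 and compound 3.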